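The compounds below may be only part of what the source reports. "The series", "measured", "known", "first", "only" and "open" are said of these compounds alone.

Values in a functional assay on SW480 cells (Homo sapiens) for antiproliferative activity, read by MTT assay, with a stated time of 48 h (a higher number here means a weaker inhibitor, a lower number a stronger inhibitor), follow.
compound 1 `CCCCC(CCO)n1cnc2c(OC)ncnc21` gives > 50000 nM (a limit)
compound 2 `CCCCCC(CCO)n1cnc2c(OC)ncnc21` gives > 50000 nM (a limit)
compound 3 `CCCCCCC(CCO)n1cnc2c(OC)ncnc21` gives > 50000 nM (a limit)

Compound 3 stands at a limit and not at a number. the limit of > 50000 nM in this assay, at which 3 of the 3 values shown sit, is all the series shows so far. Compound 4 `CCCCCCC(CCO)n1cnc2cncnc21` differs by hydrogen in place of methoxy on an aromatic carbon on the shared core, that is hydrogen in place of methoxy on an aromatic carbon. The measured steps a step that the two limits leave unreadable from compound 1 to compound 2 and a step that the two limits leave unreadable from compound 1 to compound 3 and a step that the two limits leave unreadable from compound 2 to compound 3 all sit on the chain and leave the methoxy untouched, so they offer no size to carry over. No step beyond the scatter is expected in this assay and no direction is favoured. The expected change is a number no higher from compound 3 to compound 4 (the limit leaves the size open) as an estimate. Compound 4 is estimated at 50000 nM with an expected range from 20000 nM to 100000 nM and may well read as a limit again.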

Compound 4, half-maximal inhibitory concentration: > 50000 nM
Compound 4: no number, only a limit; the forecaster's own chance of this, stated with the estimate: 80%; the middle value lies on the limit itself.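

No step can be read between compound 3 and compound 4. The compounds shown leave open whether any change on the chain or at the methoxy gives a readable number, as all values sit at one limit: the limit of > 50000 nM in this assay, at which 4 of the 4 values shown sit.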